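Halogen swap on the sulfonyl aryl of compound 1

The compounds below may be only part of what the source reports. "The series", "measured", "known", "first", "only" and "open" are said of these compounds alone.

For the measured compounds named here, compound 1 `O=S(=O)(NCCNc1nccc(-c2c(-c3cccc(F)c3)nc3sccn23)n1)c1ccc(Br)cc1` and compound 2 `COc1ccc(S(=O)(=O)NCCCNc2nccc(-c3c(-c4cccc(F)c4)nc4sccn34)n2)cc1` share the same core but differ in more than one place, so no single-point step connects them. In a functional assay on A-375 cells (Homo sapiens) for cytotoxicity, read by MTT assay (on this read-out lower numbers stand for stronger inhibition and higher numbers for weaker inhibition), compound 1 gives 13500 nM. In this assay compound 2 gives 5510 nM; compound 1 thus has the higher of the two numbers, and the gap between them lies beyond the scatter, which leaves compound 1 as the weaker of the pair. Compound 3 `O=S(=O)(NCCNc1nccc(-c2c(-c3cccc(F)c3)nc3sccn23)n1)c1ccc(Cl)cc1` has not yet been measured. It differs from compound 1 as follows: chloro in place of bromo on an aromatic carbon, in words chloro in place of bromo on an aromatic carbon, so that the (4-bromophenyl)sulfonyl group becomes (4-chlorophenyl)sulfonyl. Going by the values given here, no measured pair shows the effect of this exchange. With nothing to anchor it, the step from compound 1 to compound 3 is expected to be small and within the scatter, in either direction. The estimate for compound 3 in this assay is 15000 nM, with a range from 6000 nM to 40000 nM. This corresponds to an expected step of a 1.1-fold higher number from compound 1 to compound 3 (0.05 log units; within the scatter).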

Compound 3, half-maximal inhibitory concentration: 18600 nM
Compound 3: middle estimate off by 1.2-fold (0.09 log units), on the low side; low and high end bracket the measured number.
By their numbers in this assay, from the lowest: compound 2; then compounds 1 and 3 (each within the scatter of the next).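

In this assay, the exchange of bromo for chloro on an aromatic carbon, para to a large group, gives a 1.4-fold higher number from compound 1 to compound 3 (0.14 log units; within the scatter), the first single-point step available in the series. At this position the 4-bromophenyl and 4-chlorophenyl forms therefore cannot be told apart by this read-out, so the two halogens are interchangeable here as far as this one pair can show. No measurement at hand bears on why the pair reads this way, and a single exchange between two halogens does not show how sensitive the position is to other kinds of group.

Open, going by these compounds, is how the number responds when the halogen on this ring gives way to a trifluoromethyl, a nitrile, an amine or a carboxylic acid, or when the ring carries only hydrogen at this position. Compound 2 differs from compound 1 in more than one place, so its number cannot be assigned to any one of those differences, and a compound differing from compound 1 in a single place would be needed to separate them.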